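From 3-hydroxypiperidin-1-yl to 4-hydroxypiperidin-1-yl on a shared core

The source may report more compounds than this note shows. Statements on the series, on what has been measured and on what is new or still open speak of the compounds shown alone.

Compound 1 `O=S(=O)(c1ccccc1)c1nc2ccccc2nc1N1CCCC1`: 34800 nM
Compound 2 `O=S(=O)(c1ccccc1)c1nc2ccccc2nc1N1CCCC(O)C1`: 310 nM

Both numbers come from a functional assay on A549 cells (Homo sapiens) for cytotoxicity, read by MTT assay, with a stated time of 72 h; a lower number here means a stronger inhibitor, a higher number a weaker inhibitor. Of the two, compound 2 holds the lower number. Within the data shown here, the only measured step, a 110-fold lower number from compound 1 to compound 2 (2.05 log units; beyond the scatter), is large and beyond the scatter, and it came with 3-hydroxypiperidin-1-yl in place of pyrrolidin-1-yl on an aromatic carbon.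

Compound 3 `O=S(=O)(c1ccccc1)c1nc2ccccc2nc1N1CCC(O)CC1` keeps the shared core and carries 4-hydroxypiperidin-1-yl in place of 3-hydroxypiperidin-1-yl on an aromatic carbon, next to the ring nitrogen: 4-hydroxypiperidin-1-yl in place of 3-hydroxypiperidin-1-yl on an aromatic carbon. The measured step bears on this change only in part, as it replaced the whole group. Among the measured compounds shown here, no measured pair moves the hydroxyl alone, so the effect of its place is unknown.

With the six-membered non-aromatic ring kept, a much smaller step than the measured one is expected in this assay, probably towards a higher number, as compound 2 at 310 nM is the lowest so far. The estimated step is a 1.9-fold higher number from compound 2 to compound 3 (0.29 log units; within the scatter). The expected value for compound 3 is 600 nM, with an estimated range from 120 nM to 4000 nM.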

Compound 3, half-maximal inhibitory concentration: 2060 nM
Compound 3: the middle estimate sits 3.4-fold (0.54 log units) below what was measured; the range from low to high includes it.
By their numbers in this assay, from the lowest: compound 2; then compound 3; then compound 1.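

In this assay, the two hydroxylated groups have the same atoms joined differently, so this pair isolates the place of the hydroxyl on the six-membered non-aromatic ring, and a 6.6-fold higher number from compound 2 to compound 3 (0.82 log units; beyond the scatter) shows that this place alone moves the number, modestly but beyond the scatter. The 4-hydroxypiperidin-1-yl group still stands well clear of pyrrolidin-1-yl, with a 17-fold lower number from compound 1 to compound 3 (1.23 log units; beyond the scatter), so among these three compounds the order runs from 3-hydroxypiperidin-1-yl through 4-hydroxypiperidin-1-yl to pyrrolidin-1-yl. Nothing at hand accounts for the difference between the two hydroxyl places.

Compound 1 differs from compound 2 and compound 3 in both the ring and the hydroxyl, so the compounds shown leave open how much of its distance belongs to each, a question that a plain piperidin-1-yl group on the shared core would address. Also open, as far as these compounds go, is whether the hydroxyl itself matters, or whether an amine, a methoxy group or a carboxylic acid at the same places on the ring would give numbers like those of compound 2 and compound 3.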